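This account rests on a few compounds, and the source may have more. Where it says the series, first, only, none or still open, it means among the compounds named here.

In a functional assay on U-87MG ATCC cells (Homo sapiens) for inhibition (a lower number here means a stronger inhibitor, a higher number a weaker inhibitor), compound 1 `COc1cc(/C=C/C(=O)c2cccc(NC(=O)c3ccc(Cl)cc3)c2)ccc1O` reports > 50 ug/mL, which is a limit of the assay and not a number. Going by the values given here, compound 2 `COc1cc(/C=C/C(=O)c2cccc(NC(=O)c3ccc(Cl)c(Cl)c3)c2)ccc1O` gives 29.5 ug/mL, the only true number so far. Compound 3 `COc1cc(/C=C/C(=O)c2cccc(NC(C)=O)c2)ccc1O` carries methyl in place of 3,4-dichlorophenyl on a carbonyl carbon. Among the compounds with values here, one measured step bears on this group: an at least 1.6-fold lower number from compound 1 to compound 2 (0.22 log units; that floor lies within the scatter), a floor that lies within the scatter, so it is weak evidence. It still suggests that compound 3 will be a somewhat weaker inhibitor, with a modest step. The expected change is a 1.5-fold higher number from compound 2 to compound 3 (0.18 log units; within the scatter). For compound 3 the estimated value is 45 ug/mL, with an expected range of 20 ug/mL to 100 ug/mL.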

Compound 3, half-maximal inhibitory concentration: > 50 ug/mL
Compound 3: no number, only a limit; the forecaster's own chance of this, stated with the estimate: 50%; middle value at least 1.1-fold (0.04 log units) from the limit.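

In this assay, putting methyl in place of 3,4-dichlorophenyl on the carbonyl carbon gives an at least 1.6-fold higher number from compound 2 to compound 3 (0.22 log units; that floor lies within the scatter). Going by these compounds, the earlier pair differed by one chlorine, whereas this change removes the whole aromatic ring, and compound 3 gives only a limit of the assay, so the true size of the step stays unknown. The step from compound 1 to compound 3 cannot be read, because both ends are limits: the limit of > 50 ug/mL in this assay, at which 2 of the 3 values shown sit. On these data alone, how an amine or a longer chain would behave on this carbonyl carbon stays open.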